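Trimming a methyl from the oxazoline of compound 3

The source may report more compounds than this note shows. Statements on the series, on what has been measured and on what is new or still open speak of the compounds shown alone.

Three compounds have numbers in an assay (strain Wistar) for inhibition of Fatty-acid amide hydrolase 1 (Rattus norvegicus), read by scintillation counting; on this read-out lower numbers stand for stronger inhibition and higher numbers for weaker inhibition. Compound 1 `CCCNC(=O)Oc1cccc(-c2nc3ncncc3o2)c1` gives 4500 nM. Compound 2 `CC1(C)COC(c2cccc(OC(=O)NC3CCCC3)c2)=N1` gives 65 nM, and compound 3 `CC1(C)COC(c2cccc(OC(=O)NC3CCCCC3)c2)=N1` gives 46 nM, the lowest of the three numbers; compound 2 is its nearest neighbour, while compound 1 stands far above it, beyond the scatter. For the measured compounds named here, the only measured step between compounds that differ in one place, a 1.4-fold lower number from compound 2 to compound 3 (0.15 log units; within the scatter), concerns the group on the amide-type nitrogen and lies within the scatter.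

Compound 4 `C[C@H]1COC(c2cccc(OC(=O)NC3CCCCC3)c2)=N1` has not yet been measured. It differs from compound 3 at a different place: a group of 6 heavy atoms (4 carbon, 1 nitrogen, 1 oxygen; one five-membered non-aromatic ring with 2 hetero atoms) in place of a group of 7 heavy atoms (5 carbon, 1 nitrogen, 1 oxygen; one five-membered non-aromatic ring with 2 hetero atoms), on an aromatic carbon. Going by the values given here, no measured step touches this part of the molecule. Compound 1 and compound 3 differ in two places at once, so their two values cannot be read as a single step. Among the compounds with values here, the change from compound 3 to compound 4 removes one carbon and adds a defined stereocentre while leaving the ring and its hetero atoms in place, and the one measured step, a 1.4-fold lower number from compound 2 to compound 3 (0.15 log units; within the scatter), shows how little a small carbon change moved this assay. Compound 4 is therefore expected to give 55 nM, somewhere between 18 nM and 170 nM, which means an expected step of a 1.2-fold higher number from compound 3 to compound 4 (0.08 log units; within the scatter), not beyond the scatter.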

Compound 4, half-maximal inhibitory concentration: 51 nM
Compound 4: the middle estimate sits 1.1-fold (0.03 log units) above what was measured, and the stated range covers the measured number.
By their numbers in this assay, from the lowest: compounds 3, 4 and 2 (each within the scatter of the next); then compound 1.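

For the compounds shown here, this is the first measured step at the five-membered non-aromatic ring on an aromatic carbon: in this assay, the step is a 1.1-fold higher number from compound 3 to compound 4 (0.04 log units; within the scatter), so the group of 6 heavy atoms, with its 1 defined stereocentre, can stand in place of the group of 7 heavy atoms without a change beyond the scatter. Until now the only readable step, a 1.4-fold lower number from compound 2 to compound 3 (0.15 log units; within the scatter), concerned the group on the amide-type nitrogen, and the new step shows the same small size at a second place in the molecule, with no compound among these single-place steps going against that. Nothing measured here offers an explanation for this result, and the step cannot separate the removal of one carbon from the arrival of the stereocentre.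

The compounds shown leave open how the mirror-image form of compound 4, or the same ring carrying no methyl at all, would read in this assay. They also leave open whether a larger group on that ring, such as a phenyl or a benzyl, would still give a step within the scatter.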